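A few compounds are considered here, and "the series" means these few. Any claim that something is new, unique, unknown or untested is made for them only; others in the source may bear on it.

Measured so far:
compound 1 `Cc1ccccc1/C(=C\c1cc(OCc2ccsc2)ccc1Br)C(=O)O` gives 3000 nM
compound 2 `N#Cc1ccc(OCc2ccsc2)cc1/C=C(/C(=O)O)c1ccccc1Cl` gives 200 nM
compound 3 `Cc1ccccc1/C(=C\c1cc(OCc2ccsc2)ccc1C#N)C(=O)O` gives 300 nM

All three values come from an assay on A10 cells for binding affinity to Endothelin-1 receptor (Rattus norvegicus); a lower number here means a stronger inhibitor, a higher number a weaker inhibitor. Among them compound 3 stands second highest, and its nearest neighbour is compound 2, a gap within the usual scatter; its furthest is compound 1, a gap beyond it. The two measured steps both end at compound 3: cyano in place of bromo on an aromatic carbon gave a 10-fold lower number from compound 1 to compound 3 (1.00 log units; beyond the scatter), and methyl in place of chloro on an aromatic carbon gave a 1.5-fold higher number from compound 2 to compound 3 (0.18 log units; within the scatter). Both steps change groups on the aromatic rings and leave the carboxy untouched.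

Compound 4 `Cc1ccccc1/C(=C\c1cc(OCc2ccsc2)ccc1C#N)CO` differs from compound 3 in another place: hydroxymethyl in place of carboxy on a double-bonded chain carbon bound to an aromatic carbon and a double-bonded chain carbon. Going by the values given here, no measured step here touches that group, so the measured steps give no direct size to expect, and the estimate for compound 4 rests on the unmeasured nature of this exchange, carrying a wide range. Compound 4 is expected to give a higher number, an estimated step of a 33-fold higher number from compound 3 to compound 4 (1.52 log units; beyond the scatter), landing near 10000 nM with a range from 1000 nM to 100000 nM.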

Compound 4, half-maximal inhibitory concentration: 300 nM
Compound 4: the middle estimate sits 33-fold (1.52 log units) above what was measured, and the stated range ends above it.
By their numbers in this assay, from the lowest: compounds 2, 3 and 4 (each within the scatter of the next); then compound 1.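

Placing hydroxymethyl where carboxy stood on the double-bonded chain carbon gave no change at the digits printed from compound 3 to compound 4 (within the scatter) in this assay. Compounds 1, 2 and 3 all carry carboxy, so they could not show whether this group matters; compound 4 shows that, on this core with the nitrile and methyl groups of compound 3, carboxy is not required to hold the number in this assay. No available evidence explains why the exchange leaves the number in place.

Still open, as far as these compounds go, is whether a plain methyl, an amine or a longer chain at this place would hold the number as well, which would show how much this position accepts. Also open, from the compounds shown here alone, is whether hydroxymethyl would behave the same way on the bromo core of compound 1, which gives 3000 nM with carboxy.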